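The source may report more compounds than this note shows. Statements on the series, on what has been measured and on what is new or still open speak of the compounds shown alone.

Compound 1 `Cc1ccc(S(=O)(=O)Oc2ccccc2/C=C(\C#N)C(=O)Nc2nnc(Cc3cccc4ccccc34)s2)cc1`: 73%
Compound 2 `N#C/C(=C\c1ccccc1OS(=O)(=O)c1ccccc1[N+](=O)[O-])C(=O)Nc1nnc(Cc2cccc3ccccc23)s1`: 66%

In a functional assay on RS4-11 cells (Homo sapiens) for inhibition, read by CCK-8 assay, with a stated time of 48 h, tested at 20 uM (on this read-out lower numbers stand for less inhibition of growth and higher numbers for more inhibition of growth at the one concentration tested), compound 2 gives 66%, which lies within the scatter of compound 1 at 73%. Compound 3 `Cc1ccc(Cc2nnc(NC(=O)/C(C#N)=C/c3ccccc3OS(=O)(=O)c3ccccc3[N+](=O)[O-])s2)cc1` is not yet measured. It differs from compound 2 in one place: 4-methylphenyl in place of naphthalen-1-yl on a saturated chain carbon bound to an aromatic carbon. In other words, a 4-methylbenzyl replaces a (naphthalen-1-yl)methyl.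

Within the data shown here, only one measured step exists, a number 7 percentage points lower from compound 1 to compound 2 (within the scatter). It lies within the scatter, but it concerns a different place, with 2-nitrophenyl in place of 4-methylphenyl on a sulfonyl sulfur. Among the measured compounds shown here, no measured compound shows what a change on the saturated chain carbon does, so neither direction is supported and no step beyond the scatter is expected. The range must stay wide.

The expected change is a number 6 percentage points lower from compound 2 to compound 3 (within the scatter). For compound 3 the estimated value is 60%, with an expected range from 38% to 80%.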

Compound 3, percent growth inhibition at one concentration: "not active" (no number reported)
Compound 3: no number reported, and the estimate cannot be compared.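

Among these compounds, compound 3 is reported only as "not active", with no number, so no step from compound 2 to compound 3 can be read. Nothing shown explains this result. The compounds shown leave open how far growth inhibition changes when 4-methylbenzyl replaces (naphthalen-1-yl)methyl.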